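Methylthio for fluoro on the amide aryl group

The compounds below may be only part of what the source reports. "The series", "measured", "known", "first", "only" and "open" are said of these compounds alone.

Measured so far:
compound 1 `CCc1cccc(NC(=O)CN2CCC(c3cccc[n+]3[O-])CC2)c1`: 95 nM
compound 2 `Cc1cc(Br)ccc1NC(=O)CN1CCC(c2cccc[n+]2[O-])CC1`: 66 nM
compound 3 `O=C(CN1CCC(c2cccc[n+]2[O-])CC1)Nc1ccccc1F`: 270 nM

All three share one core and differ only in the aromatic group on the amide-type nitrogen. In a functional assay on HEK293 cells for agonist activity at D(4) dopamine receptor (Homo sapiens), read by FLIPR (on this read-out lower numbers stand for an effect already at smaller amounts and higher numbers for an effect only at larger amounts of compound), compound 3 gives the highest number of the three: a 2.8-fold higher number from compound 1 to compound 3 (0.45 log units; beyond the scatter) and a 4.1-fold higher number from compound 2 to compound 3 (0.61 log units; beyond the scatter), both beyond the scatter, while a 1.4-fold lower number from compound 1 to compound 2 (0.16 log units; within the scatter) stays within it.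

Compound 4 `CSc1cccc(NC(=O)CN2CCC(c3cccc[n+]3[O-])CC2)c1` has not been measured. It differs from compound 3 in one place: 3-(methylsulfanyl)phenyl in place of 2-fluorophenyl on an amide-type nitrogen. The group entering resembles the 3-ethylphenyl of compound 1 in that a small substituent sits in the same printed position of the ring, so the step from compound 1 to compound 3 is the closest guide, and it was modest and upward. Reversing a change of that kind should bring the number back down by a modest amount; no measured pair shows the methylsulfanyl group itself, so the exact size is uncertain.

Compound 4 is therefore expected to give 100 nM (range 40 nM to 250 nM), an estimated 2.7-fold lower number from compound 3 to compound 4 (0.43 log units; beyond the scatter) in this assay.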

Compound 4, half-maximal effective concentration: 100 nM
Estimate against measurement, compound 4: no gap at the digits printed, within the range that was stated.
By their numbers in this assay, from the lowest: compounds 2, 1 and 4 (each within the scatter of the next); then compound 3.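

For the compounds shown here, compound 4 gives the first step in which only a single substituent changes, methylsulfanyl in place of ethyl on an aromatic carbon, and in this assay that step is a 1.1-fold higher number from compound 1 to compound 4 (0.02 log units; within the scatter), so this read-out does not separate the two groups. Against a differently substituted ring the result is similar, with a 1.5-fold higher number from compound 2 to compound 4 (0.18 log units; within the scatter), which means compounds 1, 2 and 4 now form a group of three whose numbers lie within the scatter of one another, although their aromatic groups on the amide-type nitrogen differ. Compound 3 stands apart from all three, and a 2.7-fold lower number from compound 3 to compound 4 (0.43 log units; beyond the scatter) adds a third step beyond the scatter, yet nothing available explains this separation or the likeness of the other three.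

A 3-fluorophenyl group on the amide-type nitrogen would help show whether the fluorine itself or its place on the ring goes with the higher number of compound 3. As far as these compounds go, it also remains open whether a methoxy group, an amine or a carboxylic acid in place of the ethyl of compound 1 would stay within the same narrow range.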